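The compounds below may be only part of what the source reports. "The series", "measured", "known", "first", "only" and "open" are said of these compounds alone.

Series notes. Compound 1 `CCc1cc(C(C)=O)c(O)cc1OCCCCC#N`, compound 2 `CCCc1cc(C(C)=O)c(O)cc1OCCCCC#N` and compound 3 `CCCCCc1cc(C(C)=O)c(O)cc1OCCCCC#N` carry the same substituted core and differ only in the chain on it. In an assay on isolated protein for inhibition of leukotriene B4 receptor 1 (Homo sapiens), tested at 10 uM (a higher number here means more inhibition at the concentration tested (going by the name of the read-out), a lower number less inhibition), compound 1 gives 92%, compound 2 gives 84% and compound 3 gives 31%. The change from compound 1 to compound 2 is methyl in place of hydrogen on a saturated chain carbon, two bonds along the chain from an aromatic carbon; the step it made, a number 8 percentage points lower from compound 1 to compound 2 (within the scatter), lies within the scatter. Lengthening the chain further gave a number 61 percentage points lower from compound 1 to compound 3 (beyond the scatter) and a number 53 percentage points lower from compound 2 to compound 3 (beyond the scatter), both beyond the scatter, so compound 3 stands lowest of the three.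

Compound 4 `CCCCCCc1cc(C(C)=O)c(O)cc1OCCCCC#N` is not yet measured. It differs from compound 3 by methyl in place of hydrogen on a saturated chain carbon, five bonds along the chain from an aromatic carbon. This is the same kind of change as that from compound 1 to compound 2, not the same: there the methyl entered two bonds along the chain from an aromatic carbon, here five bonds along the chain from an aromatic carbon. The two cores differ by propyl in place of hydrogen on a saturated chain carbon, two bonds along the chain from an aromatic carbon.

In this assay a step of a number 11 percentage points lower from compound 3 to compound 4 (beyond the scatter) is expected from compound 3 to compound 4, somewhat larger than the earlier one, because compound 3 already sits after the drop a number 53 percentage points lower from compound 2 to compound 3 (beyond the scatter) and each added chain carbon so far has lowered the read-out. For compound 4 the estimate is 20%. For compound 4 the expected range runs from 5% to 40%.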

Compound 4, a percentage reported as inhibition, at one concentration (the size of the read-out at that concentration, not a potency): 51%
Beside the measured number, compound 4's estimate is 31 percentage points below it; measured number above the stated range.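

In this assay, methyl in place of hydrogen does not carry over as a fixed step from one core to another, and the step of a number 20 percentage points higher from compound 3 to compound 4 (beyond the scatter) runs against the fall in the read-out seen up to compound 3: the same change on two cores in this assay, a number 8 percentage points lower (within the scatter) from compound 1 to compound 2 and a number 20 percentage points higher (beyond the scatter) from compound 3 to compound 4, 28 percentage points apart, beyond the scatter of two such steps. The longer change does not carry over as a fixed step either, with compound 4 still standing a number 33 percentage points lower from compound 2 to compound 4 (beyond the scatter) and a number 41 percentage points lower from compound 1 to compound 4 (beyond the scatter): the same change on two cores in this assay, a number 61 percentage points lower (beyond the scatter) from compound 1 to compound 3 and a number 33 percentage points lower (beyond the scatter) from compound 2 to compound 4, 28 percentage points apart, beyond the scatter of two such steps. These results show that the effect of adding to the chain depends on the chain already present, but they rest on few pairs at one concentration and do not show why the steps differ or give any potency.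

As far as these compounds go, whether a longer chain than that of compound 4 would raise the read-out further or lower it again remains open. Also open, from the compounds shown here alone, is how a branched chain in the same place, or a carboxylic acid in place of the nitrile, would read in this assay.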